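Chain Lengthening on Two Related Cores and Cytotoxicity

The source may report more compounds than this note shows. Statements on the series, on what has been measured and on what is new or still open speak of the compounds shown alone.

Compound 1 `CCCCCCCNc1cnc(C(=O)NCc2ccccc2)cn1` gives in an ADME assay on HeLa cells (Homo sapiens) for cytotoxicity, read by microscopy, with a stated time of 6 days (on this read-out higher numbers stand for lower toxicity in this test and lower numbers for higher toxicity in this test), a value that is a limit of the assay, > 100000 nM.
Compound 2 `CCCCCCCCNc1cnc(C(=O)NCc2ccccc2)cn1` gives in this assay 100000 nM.
Compound 3 `CCCCCCNc1nccnc1C(=O)NCc1ccccc1` gives in this assay a value that is a limit of the assay, > 100000 nM.

From compound 1 to compound 2 the change is methyl in place of hydrogen on a saturated chain carbon, seven bonds along the chain from a nitrogen on an aromatic ring, and the step is a number no higher from compound 1 to compound 2 (the limit leaves the size open). Compound 3 carries a different core; the difference between the two cores is not broken down here. Two of the three values sit at the same point, (the limit of > 100000 nM in this assay, at which 2 of the 3 values shown sit).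

Compound 4 `CCCCCCCNc1nccnc1C(=O)NCc1ccccc1` has not yet been measured in this assay. It differs from compound 3 by methyl in place of hydrogen on a saturated chain carbon, six bonds along the chain from a nitrogen on an aromatic ring. This is the same kind of change as that from compound 1 to compound 2, but here the methyl sits six bonds along the chain from a nitrogen on an aromatic ring, where before it sat seven bonds along the chain.

The expected step is a number no higher from compound 3 to compound 4 (the limit leaves the size open), resting on the measured a number no higher from compound 1 to compound 2 (the limit leaves the size open). Compound 4 is therefore estimated at 100000 nM, between 50000 nM and 200000 nM.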

Compound 4, minimum cytotoxic concentration: > 100000 nM
Compound 4 was reported as a limit; the forecaster's own chance of this, stated with the estimate: 60%; the middle value lies on the limit itself.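

No step can be read from compound 3 to compound 4 in this assay, because both compounds are reported only as limits of the assay: (the limit of > 100000 nM in this assay, at which 3 of the 4 values shown sit).

The compounds shown leave open whether the added methyl changes the read-out on the core of compound 3 at all, and whether that core differs from the core of compound 1.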